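Halogen Series on the Sulfonyl Ring: Chloro to Bromo

The source may report more compounds than this note shows. Statements on the series, on what has been measured and on what is new or still open speak of the compounds shown alone.

Within the data shown here, compound 2 `O=C(/C=C/c1ccc(F)cc1)NS(=O)(=O)c1ccc(Cl)cc1` has the highest of the two numbers so far in a functional assay on B16-F10 cells (Mus musculus) for antiproliferative activity, read by ELISA and MTT assay, with a stated time of 48 h; on this read-out lower numbers stand for stronger inhibition and higher numbers for weaker inhibition: compound 2 gives 2.6 ug/mL, while compound 1 `O=C(/C=C/c1ccc(F)cc1)NS(=O)(=O)c1ccc(F)cc1` gives 0.8 ug/mL. Among the measured compounds shown here, the single step between them, a 3.3-fold higher number from compound 1 to compound 2 (0.51 log units; beyond the scatter), is the only measured step that bears on the next change. Compound 3 `O=C(/C=C/c1ccc(F)cc1)NS(=O)(=O)c1ccc(Br)cc1` differs from compound 2 by bromo in place of chloro on an aromatic carbon, on an aromatic carbon of a six-membered aromatic ring of carbon only, para to a large group. Since one halogen exchange at that place already raised the number by a modest amount, a second exchange in the same series is expected to move it in the same direction or not beyond the scatter. Compound 3 is therefore expected to give about 4 ug/mL, with a range from 1.5 ug/mL to 10 ug/mL. The expected step is a 1.5-fold higher number from compound 2 to compound 3 (0.19 log units; within the scatter), modest at most.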

Compound 3, half-maximal inhibitory concentration: 2.8 ug/mL
Estimate against measurement, compound 3: 1.4-fold (0.15 log units) above; the range from low to high includes it.
By their numbers in this assay, from the lowest: compound 1; then compounds 2 and 3 (each within the scatter of the next).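

In this assay, bromo in place of chloro on an aromatic carbon, para to a large group, gives a 1.1-fold higher number from compound 2 to compound 3 (0.03 log units; within the scatter), so compound 2 and compound 3 cannot be told apart at this place. Compound 1 stands apart from both, since bromo in place of fluoro gives a 3.5-fold higher number from compound 1 to compound 3 (0.54 log units; beyond the scatter), a step close in size to a 3.3-fold higher number from compound 1 to compound 2 (0.51 log units; beyond the scatter), and among these three halogens only fluoro separates from the others. Nothing available explains why chloro and bromo read alike here while fluoro does not.

From the compounds shown here alone, all three compounds carry a halogen at this place, so how a methoxy group, an amine or a carboxylic acid there would compare remains open. Going by these compounds, the rest of the shared core is the same throughout, so what a change elsewhere would do is also open.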